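This account rests on a few compounds, and the source may have more. Where it says the series, first, only, none or still open, it means among the compounds named here.

In a functional assay on COLO 205 cells (Homo sapiens) for inhibition, read by sulforhodamine B assay, tested at 10 uM (on this read-out lower numbers stand for less inhibition of growth and higher numbers for more inhibition of growth at the one concentration tested), three members of this series have been measured. Compound 1 `COc1cc(C2CC(c3ccc(OCc4cn(Cc5ccc([N+](=O)[O-])cc5)nn4)cc3)=NN2C(C)=O)ccc1Oc1cn(Cc2ccc([N+](=O)[O-])cc2)nn1` gives 27%, compound 2 `COc1cc(C2CC(c3ccc([N+](=O)[O-])cc3)=NN2C(C)=O)ccc1OCc1cn(Cc2ccc([N+](=O)[O-])cc2)nn1` gives 33%, and compound 3 `COc1cc(C2CC(c3ccc(Br)cc3)=NN2C(C)=O)ccc1OCc1cn(Cc2ccc([N+](=O)[O-])cc2)nn1` gives 26%. All three numbers lie within the scatter of one another, so compound 3 cannot be set apart from compound 1 or compound 2 on this read-out; it simply sits among them. Among the measured compounds shown here, the one single-point step available, a number 7 percentage points lower from compound 2 to compound 3 (within the scatter), likewise stays inside the scatter.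

Compound 4 `COc1cc(C2CC(c3ccccc3)=NN2C(C)=O)ccc1OCc1cn(Cc2ccc([N+](=O)[O-])cc2)nn1` is the next compound in the series. The change from compound 3 is hydrogen in place of bromo on an aromatic carbon. This bears some resemblance to the step already seen, in that a substituent on the same aromatic carbon is exchanged, and that step moved the number only within the scatter. No other step in the shown data touches this position. The expectation is therefore that the step from compound 3 to compound 4 will also stay within the scatter, with no direction that can be relied upon; the estimated step is no change at the digits printed from compound 3 to compound 4 (within the scatter). On that basis compound 4 is estimated to give 26% in this assay, with a plausible range from 14% to 38%.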

Compound 4, percent growth inhibition at one concentration: 7%
Compound 4: the middle estimate sits 19 percentage points above what was measured; the whole stated range lies above it.
By their numbers in this assay, from the lowest: compound 4; then compounds 3, 1 and 2 (each within the scatter of the next).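

In this assay this position, para to a large group on the six-membered aromatic ring, turns out to be sensitive to the loss of its substituent, which the exchange of one substituent for another had not revealed: the step with bromo in place of nitro was a number 7 percentage points lower from compound 2 to compound 3 (within the scatter) and stayed inside the scatter. Taking the substituent away altogether and leaving hydrogen, so that 4-bromophenyl becomes phenyl, gives a number 19 percentage points lower from compound 3 to compound 4 (beyond the scatter) and, measured from the nitro compound, a number 26 percentage points lower from compound 2 to compound 4 (beyond the scatter) so among these three compounds the unsubstituted phenyl alone stands apart, while bromo and nitro cannot be told apart. Nothing available explains why hydrogen differs from these two groups at this position.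

The compounds shown leave open whether the number depends on the identity of the group on this carbon or only on a group other than hydrogen being present, as bromo and nitro are the only two substituents set against hydrogen here. Going by these compounds, a methoxy group, an amine or a carboxylic acid on the same carbon would test this, and whether the same step holds on the core of compound 1 also stays open.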